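Carbonyl substituent change from compound 2 to compound 3

The source may hold more compounds than are shown below. What is called first, only, known or untested is meant among the compounds shown, and "the series" means these compounds.

Compound 1 (`COc1ccc(CN(C(=O)C=C(C)C)c2cc(OC)c(OC)c(OC)c2)cc1O`): 320 nM
Compound 2 (`CCC/C=C/C(=O)N(Cc1ccc(OC)c(O)c1)c1cc(OC)c(OC)c(OC)c1`): 70 nM

In a functional assay on MGC-803 cells (Homo sapiens) for inhibition, read by MTT assay, with a stated time of 48 h (a higher number here means a weaker inhibitor, a lower number a stronger inhibitor), compound 2 holds the lower of the two numbers. Compound 3 (`COc1ccc(CN(C(=O)CO)c2cc(OC)c(OC)c(OC)c2)cc1O`) carries hydroxymethyl in place of pent-1-en-1-yl on a carbonyl carbon. Going by the values given here, only one measured step bears on this place, the modest 4.6-fold lower number from compound 1 to compound 2 (0.66 log units; beyond the scatter) (beyond the scatter), and there the group changed was also pent-1-en-1-yl. The present change is larger in kind, so the expected step is a 17-fold higher number from compound 2 to compound 3 (1.23 log units; beyond the scatter) and it runs towards a weaker inhibitor. In this assay compound 3 is estimated at 1200 nM (expected range 250 nM to 6000 nM).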

Compound 3, half-maximal inhibitory concentration: 160 nM
For compound 3 the middle estimate is 7.5-fold (0.88 log units) above the measured one; measured number below the stated range.
By their numbers in this assay, from the lowest: compound 2; then compounds 3 and 1 (each within the scatter of the next).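

In this assay, the carbonyl position accepts a much shorter group carrying a hydrogen-bond donor, at a modest cost (a 2.3-fold higher number from compound 2 to compound 3 (0.36 log units; beyond the scatter)). Set against the 2-methylprop-1-en-1-yl group, hydroxymethyl gives a step within the scatter (a 2.0-fold lower number from compound 1 to compound 3 (0.30 log units; within the scatter)), so a double bond outside aromatic rings is not needed for activity at this level. No measurement here explains either step.

The change from pent-1-en-1-yl alters chain length, double bond and hydroxyl at once, and these effects remain unseparated. A saturated pentyl chain, 2-hydroxyethyl or an aminomethyl group at this place would begin to part them.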